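This account rests on a few compounds, and the source may have more. Where it says the series, first, only, none or still open, it means among the compounds named here.

Measured compounds:
compound 1, `Fc1ccc(-c2cc(OC[C@@H]3CCN3)cnc2Cl)cn1`: 0.0049 nM
compound 2, `Clc1ncc(OC[C@@H]2CCN2)cc1-c1ccc(Br)nc1`: 0.0043 nM
compound 3, `Fc1cc(/C=C/c2cc(OC[C@@H]3CCCN3)cnc2Cl)ccn1`: 0.0094 nM

All three were tested in an assay on membranes from brain with Neuronal acetylcholine receptor; alpha4/beta2 (Rattus norvegicus) as the target; a lower number here means a stronger inhibitor, a higher number a weaker inhibitor. Compound 2 differs from compound 1 by bromo in place of fluoro on an aromatic carbon, and that step gave a 1.1-fold lower number from compound 1 to compound 2 (0.06 log units; within the scatter). Compound 4, `Clc1ncc(OC[C@@H]2CCCN2)cc1/C=C/c1ccnc(Br)c1`, has not yet been measured; it differs from compound 3 by bromo in place of fluoro on an aromatic carbon. The difference between the core of compound 3 and the core of compound 1 is not broken down here. Around the place of the change the two cases differ: in compound 1 the fluoro sits para to a large group, in compound 3 meta to a large group, so the two changes are the same kind of change, not the same. Because a 1.1-fold lower number from compound 1 to compound 2 (0.06 log units; within the scatter) lay within the scatter, the corresponding step is expected to be small, a 1.1-fold lower number from compound 3 to compound 4 (0.04 log units; within the scatter). Compound 4 is therefore estimated at 0.0085 nM, with a likely range from 0.003 nM to 0.025 nM.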

Compound 4, inhibition constant: 0.0056 nM
For compound 4 the middle estimate is 1.5-fold (0.18 log units) above the measured one; the measured number falls inside the stated range.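

In this assay, bromo in place of fluoro gave a 1.7-fold lower number from compound 3 to compound 4 (0.22 log units; within the scatter), so on this second core the swap again stays within the scatter. Two pairs of compounds cannot show that the same would hold on every core in the series, and they do not explain why the two groups give such similar numbers. Set side by side, the two steps show that this change carried over from one core to the other without a detectable difference: the same change on two cores in this assay, a 1.1-fold lower number (0.06 log units; within the scatter) from compound 1 to compound 2 and a 1.7-fold lower number (0.22 log units; within the scatter) from compound 3 to compound 4, 1.5-fold (0.17 log units) apart, within the scatter of two such steps

The compounds shown leave open whether other groups at this place, such as methyl, methoxy or an amine, would match fluoro and bromo. They also leave open how these compounds compare on any other receptor.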